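Swapping the aryl group on the shared core: compound 4

The compounds below may be only part of what the source reports. "The series", "measured", "known", "first", "only" and "open" are said of these compounds alone.

Measured so far:
compound 1 `O=C(CCCCCCc1ccccc1)c1ncc(-c2ccccc2F)o1`: 110 nM
compound 2 `Nc1cccc(-c2cnc(C(=O)CCCCCCc3ccccc3)o2)c1`: 19 nM
compound 3 `NC(=O)c1ccc(-c2cnc(C(=O)CCCCCCc3ccccc3)o2)cc1`: 10 nM

All three were tested in an assay (Rattus norvegicus) for inhibition of Fatty-acid amide hydrolase 1 (Homo sapiens); on this read-out lower numbers stand for stronger inhibition and higher numbers for weaker inhibition. Compound 1 stands at the highest number of the three, so it is the weakest inhibitor shown here; compound 2 sits a 5.8-fold lower number from compound 1 to compound 2 (0.76 log units; beyond the scatter) below it, and compound 3 a further step away, an 11-fold lower number from compound 1 to compound 3 (1.04 log units; beyond the scatter). Compound 2 and compound 3 lie within the scatter of each other, a 1.9-fold lower number from compound 2 to compound 3 (0.28 log units; within the scatter).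

Compound 4 `Cc1ccnc(-c2cnc(C(=O)CCCCCCc3ccccc3)o2)c1` has not yet been measured. It differs from compound 1 in one place: 4-methylpyridin-2-yl in place of 2-fluorophenyl on an aromatic carbon.

Going by the values given here, two measured steps bear on this change: a 5.8-fold lower number from compound 1 to compound 2 (0.76 log units; beyond the scatter) and an 11-fold lower number from compound 1 to compound 3 (1.04 log units; beyond the scatter). Both also replace the 2-fluorophenyl of compound 1 on the same aromatic carbon. Each gave a lower number, one modest, one large. Compound 4 brings a different six-membered ring, so the expected step is a lower number of modest size, a 2.8-fold lower number from compound 1 to compound 4 (0.44 log units; beyond the scatter). Compound 4 is therefore estimated at 40 nM, with a range from 15 nM to 120 nM.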

Compound 4, inhibition constant: 0.6 nM
Compound 4: middle estimate off by 67-fold (1.82 log units), on the high side; measured number outside the range, below it.
By their numbers in this assay, from the lowest: compound 4; then compounds 3 and 2 (each within the scatter of the next); then compound 1.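

In this assay this position turns out to hold far more potential than the two substituted phenyl groups suggested, with a drop of a 180-fold lower number from compound 1 to compound 4 (2.26 log units; beyond the scatter) once 4-methylpyridin-2-yl enters. The better earlier compounds are also clearly passed, by a 17-fold lower number from compound 3 to compound 4 (1.22 log units; beyond the scatter) and by a 32-fold lower number from compound 2 to compound 4 (1.50 log units; beyond the scatter), which makes compound 4 the strongest inhibitor of the four. It is also the only one shown with a hetero atom in this six-membered aromatic ring, though no measurement here explains why the number falls so far.

The change brings in a ring nitrogen and a methyl together, so their shares of the gain remain unseparated. Plain pyridin-2-yl and 4-methylphenyl at this position would tell the two apart.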